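Removing a fluoro from a weak antiproliferative sulfonamide

The source may report more compounds than this note shows. Statements on the series, on what has been measured and on what is new or still open speak of the compounds shown alone.

Compound 1 `O=C1O[C@H]([C@@H](O)Cn2cc(CNS(=O)(=O)c3ccc(Cl)cc3F)nn2)C(OCc2ccccc2)=C1OCc1ccccc1` was tested in a functional assay on HeLa cells (Homo sapiens) for antiproliferative activity, read by MTT assay, with a stated time of 72 h (on this read-out higher numbers stand for weaker inhibition and lower numbers for stronger inhibition), and gives 20700 nM, the lowest of the two plain numbers shown. Compound 2 `O=C1O/C(=C\Cn2cc(-c3ccc(Br)cc3)nn2)C(OCc2ccccc2)=C1OCc1ccccc1` gives 24300 nM in this assay, and the two numbers lie within the scatter of each other. Compound 3 `COc1ccccc1-c1cn(C/C=C2\OC(=O)C(OCc3ccccc3)=C2OCc2ccccc2)nn1` reaches only a limit in this assay, namely > 100000 nM, which is the limit of > 100000 nM in this assay, at which 1 of the 3 values shown sits. Within the data shown here, the single measured step, an at least 4.1-fold higher number from compound 2 to compound 3 (0.61 log units; beyond the scatter), alters a different part of the molecule than the step followed here. Compound 4 `O=C1O[C@H]([C@@H](O)Cn2cc(CNS(=O)(=O)c3ccc(Cl)cc3)nn2)C(OCc2ccccc2)=C1OCc1ccccc1` differs from compound 1 by hydrogen in place of fluoro on an aromatic carbon. Among the measured compounds shown here, no measured step covers this change, so no movement beyond the scatter is expected, a step of a 1.1-fold higher number from compound 1 to compound 4 (0.03 log units; within the scatter). Compound 4 is therefore estimated at 22000 nM, with a range from 8000 nM to 60000 nM.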

Compound 4, half-maximal inhibitory concentration: 13600 nM
The estimate for compound 4 lay 1.6-fold (0.21 log units) above the measured number; the measured number falls inside the stated range.
By their numbers in this assay, from the lowest: compounds 4, 1 and 2 (each within the scatter of the next). At a limit, above all of these: compound 3.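

In this assay the change from 4-chloro-2-fluorophenyl to 4-chlorophenyl gives a 1.5-fold lower number from compound 1 to compound 4 (0.18 log units; within the scatter), so this fluoro can be replaced by hydrogen without a change that can be told from repeat measurements. Among these compounds, this is the only reading at this position, and it shows that the fluoro is not needed for the weak activity of compound 1. Nothing shown here offers a reason for this result.

Going by these compounds, whether an amine or a trifluoromethyl group on this same aromatic carbon would shift the number stays open. So does the effect of replacing the chloro group.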